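The compounds below may be only part of what the source reports. "The series", "measured", "known", "first", "only" and "open" are said of these compounds alone.

Three compounds in this set share a common core and have been tested in an ADME assay (Rattus norvegicus, strain Wistar Han) for metabolic stability; a higher number here means that the compound lasts longer, a lower number that the compound disappears faster. Compound 1 `CCn1c(-c2cnc(C)nc2)nc2c(O[C@H]3CCN(C(=O)C4CC4)C3)ncnc21` gives 1.8 h. Compound 2 `CCC(=O)N1CC[C@H](Oc2ncnc3c2nc(-c2cnc(C)nc2)n3CC)C1` gives 1.2 h. Compound 3 `CCC(=O)N1CC[C@H](Nc2ncnc3c2nc(-c2cnc(C)nc2)n3CC)C1` gives 1.5 h; the difference between the core of compound 2 and the core of compound 3 is not broken down here. Compound 4 `CCn1c(-c2cnc(C)nc2)nc2c(N[C@H]3CCN(C(=O)C4CC4)C3)ncnc21` has not yet been measured.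

The change from compound 2 to compound 1 is cyclopropyl in place of ethyl on a carbonyl carbon, and it made a 1.5-fold higher number from compound 2 to compound 1 (0.18 log units; within the scatter). Compound 4 differs from compound 3 by cyclopropyl in place of ethyl on a carbonyl carbon, the same change at the same place. A similar step is expected here because a 1.5-fold higher number from compound 2 to compound 1 (0.18 log units; within the scatter) was small. The step from compound 3 to compound 4 is therefore expected to be a 1.5-fold higher number from compound 3 to compound 4 (0.17 log units; within the scatter). Compound 4 is estimated at 2.2 h, likely falling between 1.2 h and 4 h.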

Compound 4, half-life: 2.7 h
Beside the measured number, compound 4's estimate is 1.2-fold (0.09 log units) below it, and the stated range covers the measured number.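

In this assay, putting cyclopropyl in place of ethyl on the carbonyl carbon gave a 1.8-fold higher number from compound 3 to compound 4 (0.26 log units; within the scatter). Set beside the earlier step, the change carried over from one core to the other with no visible difference: the same change on two cores in this assay, a 1.5-fold higher number (0.18 log units; within the scatter) from compound 2 to compound 1 and a 1.8-fold higher number (0.26 log units; within the scatter) from compound 3 to compound 4, 1.2-fold (0.08 log units) apart, within the scatter of two such steps. Each step lies within the usual scatter of repeated measurements, however, and the pair does not show that the cyclopropyl compounds really last longer than the ethyl compounds; two cores also cannot speak for the whole series.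

The compounds shown leave open how other groups on this carbonyl carbon would behave. A longer chain such as butyl, a phenyl ring or an amine might or might not move the half-life beyond that scatter.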